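The source may hold more compounds than are shown below. What is called first, only, known or untested is meant among the compounds shown, and "the series" means these compounds.

Measured so far:
compound 1, `CC(C)c1onc(-c2ccccc2Cl)c1COc1ccc(COc2ccc(CC(=O)O)cc2)cc1` — 2500 nM
compound 2, `CC(C)c1onc(-c2ccccc2)c1COc1ccc(CCCCC(=O)O)cc1` — > 30000 nM
compound 3, `CC(C)c1onc(-c2ccccc2)c1COc1ccc(COc2ccc(C(=O)O)cc2)cc1` — 2300 nM

In an assay on HEK-293T cells for activation of Bile acid receptor (Homo sapiens), read by a luciferase reporter, with a stated time of 14 h (a higher number here means that more compound is needed for the effect, a lower number that less compound is needed), compound 3 stands at the lowest of the two numbers given, and compound 1 gives 2500 nM, which lies within the usual scatter of the value of compound 3; no order between the two can be read. Compound 2 gives only a limit in this assay, > 30000 nM. That limit is the one recorded at the limit of > 30000 nM in this assay, at which 1 of the 3 values shown sits.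

Going by the values given here, the only measured step with one change is an at least 13-fold lower number from compound 2 to compound 3 (1.11 log units; beyond the scatter): the acid-bearing chain exchanged for an aryl ether carrying the acid, with a large gain. Compound 4, `CC(C)c1onc(-c2ccccc2)c1COc1ccc(COc2ccc(CC(=O)O)cc2)cc1`, is not yet measured. It differs from compound 3 by carboxymethyl in place of carboxy on an aromatic carbon. Among the compounds with values here, this change is far smaller than the one from compound 2 to compound 3: the acid is moved out by a single chain carbon, and compound 1, which already carries the 4-(carboxymethyl)phenoxy group on a core that differs elsewhere, gives 2500 nM. Within the data shown here, no measured step isolates this one-carbon extension. The expectation is therefore a step of a 1.1-fold higher number from compound 3 to compound 4 (0.04 log units; within the scatter), within the scatter, with no direction claimed. Compound 4 is estimated at 2500 nM, expected to fall between 1000 nM and 6000 nM.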

Compound 4, half-maximal effective concentration: 11000 nM
Compound 4: middle estimate off by 4.4-fold (0.64 log units), on the low side, and the stated range ends below it.
By their numbers in this assay, from the lowest: compounds 3 and 1 (each within the scatter of the next); then compound 4. At a limit, above all of these: compound 2.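

In this assay, the acid's position on the aromatic ring proves sensitive: carboxymethyl in place of carboxy on this aromatic carbon, para to a large group, gives a 4.8-fold higher number from compound 3 to compound 4 (0.68 log units; beyond the scatter), and with carboxymethyl held fixed, hydrogen in place of chloro on an aromatic carbon gives a 4.4-fold higher number from compound 1 to compound 4 (0.64 log units; beyond the scatter), so the earlier closeness of the values of compounds 1 and 3 did not mean that the carboxymethyl group was interchangeable with carboxy on the shared core. The 4-(carboxymethyl)phenoxy group nevertheless retains a measurable advantage over the 3-carboxypropyl chain, with an at least 2.7-fold lower number from compound 2 to compound 4 (0.43 log units; beyond the scatter). Compound 2 is recorded only at a limit: the limit of > 30000 nM in this assay, at which 1 of the 4 values shown sits.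

Still open is how the chloro group behaves when the acid is carboxy rather than carboxymethyl, since no compound shown combines the two, and so whether the effects of the two changes simply add cannot be read. Also open, as far as these compounds go, is whether a longer chain carrying the carboxylic acid on the same aromatic ring would continue the direction seen here, and whether a tetrazole could stand in place of the carboxylic acid.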